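This account rests on a few compounds, and the source may have more. Where it says the series, first, only, none or still open, it means among the compounds named here.

Compound 1, `CC(=O)Nc1ccc(NC(=O)c2cn(Cc3c(F)cccc3F)c3ccc(=O)[nH]c3c2=O)cc1`, gives 24 nM in an in vitro assay on Sf21 cells for inhibition of high affinity 3',5'-cyclic-AMP phosphodiesterase 7A (Homo sapiens), read by scintillation proximity assay, with a stated time of 30 min; on this read-out lower numbers stand for stronger inhibition and higher numbers for weaker inhibition.
Compound 2, `O=C(Nc1ccccc1)c1cn(Cc2c(F)cccc2F)c2ccc(=O)[nH]c2c1=O`, gives 94 nM in this assay.
Compound 3, `O=C(NCc1ccncc1)c1ccc(NC(=O)c2cn(Cc3c(F)cccc3F)c3ccc(=O)[nH]c3c2=O)cc1`, gives 20 nM in this assay.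

Among these three, compound 3 has the lowest number, but its lead over compound 1 is only a 1.2-fold lower number from compound 1 to compound 3 (0.08 log units; within the scatter), which is within the scatter, so the two cannot be ranked against each other. Only compound 2, which carries a plain hydrogen where the others carry a substituent, clearly sits apart: a 4.7-fold lower number from compound 2 to compound 3 (0.67 log units; beyond the scatter).

Compound 4, `O=C(Nc1ccc(C(=O)N2CCOCC2)cc1)c1cn(Cc2c(F)cccc2F)c2ccc(=O)[nH]c2c1=O`, is not yet measured. It differs from compound 3 in one place: morpholin-4-yl in place of ((pyridin-4-yl)methyl)amino on a carbonyl carbon. The measured steps that bear on this are the two that change the same position. Swapping acetamido for the larger ((pyridin-4-yl)methyl)carbamoyl left the number essentially unchanged (a 1.2-fold lower number from compound 1 to compound 3 (0.08 log units; within the scatter)), while removing the group altogether raised it (a 3.9-fold higher number from compound 1 to compound 2 (0.59 log units; beyond the scatter)). Keeping a carbonyl-bearing group there while changing its outer part is therefore expected to matter little, and compound 4 is expected to land close to compound 3, with a 1.4-fold higher number from compound 3 to compound 4 (0.15 log units; within the scatter) as the estimated step. Compound 4 is thus estimated at 28 nM, within a range of 11 nM to 70 nM.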

Compound 4, half-maximal inhibitory concentration: 188 nM
Beside the measured number, compound 4's estimate is 6.7-fold (0.83 log units) below it, and the stated range ends below it.
By their numbers in this assay, from the lowest: compounds 3 and 1 (each within the scatter of the next); then compounds 2 and 4 (each within the scatter of the next).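

With the carbonyl kept in place, the outer part of this group clearly matters in this assay: morpholin-4-yl in place of ((pyridin-4-yl)methyl)amino gives a clear rise (a 9.4-fold higher number from compound 3 to compound 4 (0.97 log units; beyond the scatter)), so a carbonyl at this position does not by itself hold the number low. The (morpholin-4-yl)carbonyl group also gives a clear rise when it replaces acetamido (a 7.8-fold higher number from compound 1 to compound 4 (0.89 log units; beyond the scatter)), whereas replacing hydrogen with it gives no separable change (a 2.0-fold higher number from compound 2 to compound 4 (0.30 log units; within the scatter)), so here a substituent offers no measurable gain over hydrogen. Nothing available explains why the two outer groups differ.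

The change swaps an aromatic ring for a non-aromatic one and also removes the amide hydrogen, and the compounds shown do not separate these two differences. On these data alone, a benzylamino group or a piperidin-1-yl group at the same carbonyl carbon remains open, and either could help to pull them apart.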